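The source may hold more compounds than are shown below. What is called first, only, known or untested is meant among the compounds shown, and "the series" means these compounds.

Compound 1 `O=C(NC1(C(=O)O)CCCCC1)c1cccc2cc(-c3ccc(Cl)cc3)oc12`, compound 2 `O=C(NC1(C(=O)O)CCCCC1)c1cccc2c(Br)c(-c3ccc(Cl)cc3)oc12` and compound 3 `CCC(C)(NC(=O)c1cc(F)cc2cc(-c3ccc(C(F)(F)F)cc3)oc12)C(=O)O` have been measured in an assay on isolated protein for inhibition of endoplasmic reticulum aminopeptidase 1 (Homo sapiens), read by mass spectrometry, with stated times of 15 min and 25 min, tested at 10 uM; a higher number here means more inhibition at the concentration tested (going by the name of the read-out), a lower number less inhibition. Compound 1 gives 2.17%, compound 2 gives 4.37% and compound 3 gives 10%.

Compound 1 has the lowest of the three numbers in this assay, though both others lie within the scatter of it. Compound 4 `CC(C)(NC(=O)c1cccc2cc(-c3ccc(Cl)cc3)oc12)C(=O)O` has not yet been measured. It differs from compound 1 by 1-carboxy-1-methylethyl in place of 1-carboxycyclohexyl on an amide-type nitrogen. Among the compounds with values here, no measured step changes this part of the molecule: the only step on record, a number 2.2 percentage points higher from compound 1 to compound 2 (within the scatter), concerns the aromatic ring. Compound 3 carries a different acid group but also differs elsewhere, so its value only shows that such compounds stay in the same low region. The expectation is therefore a change no larger than the scatter, estimated as a number 1.8 percentage points higher from compound 1 to compound 4 (within the scatter). Compound 4 is expected to give about 4%, within -6% to 14%.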

Compound 4, a percentage reported as inhibition, at one concentration (the size of the read-out at that concentration, not a potency): 25.2%
For compound 4 the middle estimate is 21.2 percentage points below the measured one; the measured number lies above the stated range.
By their numbers in this assay, from the lowest: compounds 1, 2 and 3 (each within the scatter of the next); then compound 4.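

In this assay the group on the amide-type nitrogen proves able to move the read-out: 1-carboxy-1-methylethyl in place of 1-carboxycyclohexyl gives a number 23 percentage points higher from compound 1 to compound 4 (beyond the scatter) and is the only step shown that lies beyond the scatter. The change is modest, and it was read at one concentration only. Nothing available explains this difference.

On these data alone, it remains open whether the ring itself or its size matters, which a 1-carboxycyclobutyl group on the same nitrogen could help separate. As far as these compounds go, it is also open whether the step would hold with the bromo of compound 2 present.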